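The source may report more compounds than this note shows. Statements on the series, on what has been measured and on what is new or still open speak of the compounds shown alone.

Compound 1 `Cc1c(C(=O)N/N=C\c2c(O)cccc2Cl)oc2cccc(O)c12` gives 18700 nM in a functional assay on PC-3 cells (Homo sapiens) for inhibition; a higher number here means a weaker inhibitor, a lower number a stronger inhibitor. Compound 2 `Cc1c(C(=O)N/N=C\c2ccccn2)oc2cccc(O)c12` shows only a limit of the assay, >= 40000 nM. The step of an at least 2.1-fold higher number from compound 1 to compound 2 (0.33 log units; beyond the scatter) is therefore bounded by the limit of >= 40000 nM in this assay, at which 1 of the 2 values shown sits. Compound 3 `Cc1c(C(=O)N/N=C\c2ccccc2)oc2cccc(O)c12` is not yet measured; it differs from compound 2 by phenyl in place of pyridin-2-yl on a carbon with a double bond to nitrogen. For the measured compounds named here, the one measured step concerns a different ring, and no measured pair compares phenyl with pyridin-2-yl, so no direction is expected beyond the scatter. Compound 2 sits at the limit, and compound 3 is expected to stay near it, a step of a number no higher from compound 2 to compound 3 (the limit leaves the size open) in this assay. For compound 3 the estimate is 40000 nM, between 15000 nM and 100000 nM.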

Compound 3, half-maximal inhibitory concentration: 29200 nM
Beside the measured number, compound 3's estimate is 1.4-fold (0.14 log units) above it; the range from low to high includes it.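

In this assay, for the compounds shown here, the phenyl ring gives the first comparison at this position that is not tied to a limit: a 1.6-fold higher number from compound 1 to compound 3 (0.19 log units; within the scatter). The 2-chloro-6-hydroxyphenyl ring of compound 1 and the phenyl ring of compound 3 therefore cannot be told apart in this assay. Phenyl in place of pyridin-2-yl gives an at least 1.3-fold lower number from compound 2 to compound 3 (0.13 log units; that floor lies within the scatter), but the true size of this step remains unknown, as it rests on a limit for compound 2: the limit of >= 40000 nM in this assay, at which 1 of the 3 values shown sits.

The compounds shown leave open whether a ring carrying an amine or a carboxylic acid would move the number beyond the scatter. They also leave open whether a stronger inhibitor can be reached by changing this position.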